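Working notes: replacing the piperidin-1-yl amide

The compounds below may be only part of what the source reports. "The series", "measured", "known", "first", "only" and "open" are said of these compounds alone.

Measured in a functional assay on A549 cells (Homo sapiens) for antiproliferative activity, read by sulforhodamine B assay, with a stated time of 48 h; on this read-out lower numbers stand for stronger inhibition and higher numbers for weaker inhibition:
- compound 1 `O=C1CSC(c2cccc(Br)c2)N1c1ncccn1`: > 50000 nM (a limit)
- compound 2 `COc1ccccc1N1C(=O)CSC1c1cccc(C(=O)N2CCCCC2)c1`: > 50000 nM (a limit)

In this assay compound 2 gives > 50000 nM, which is a limit of the assay and not a number. The same holds for compound 1, so the data so far amount to the limit of > 50000 nM in this assay, at which 2 of the 2 values shown sit. Among the measured compounds shown here, no measured step is available to size the next change.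

Compound 3 `COc1ccccc1N1C(=O)CSC1c1cccc(C(=O)NCCCc2ccccc2)c1` keeps the core of compound 2 and has (3-phenylpropyl)amino in place of piperidin-1-yl on a carbonyl carbon. A move towards stronger inhibition in this assay is expected, though a second result at the limit remains quite possible. The estimated step is an at least 3.3-fold lower number from compound 2 to compound 3 (0.52 log units; beyond the scatter), and as it starts from a limit, it is only a rough expectation. For compound 3 the expected value is 15000 nM, with an estimated range of 2000 nM to 50000 nM.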

Compound 3, half-maximal inhibitory concentration: 31600 nM
Compound 3: middle estimate off by 2.1-fold (0.32 log units), on the low side; the range from low to high includes it.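

In this assay, among the compounds shown here, (3-phenylpropyl)amino in place of piperidin-1-yl on a carbonyl carbon gives the first value that is a number, with compound 3 at 31600 nM. The change reads as an at least 1.5-fold lower number from compound 2 to compound 3 (0.19 log units; that floor lies within the scatter), so this position admits a replacement that brings the read-out within the measurable range, though the printed floor alone does not separate the pair from the scatter. The true size of the step stays unknown because compound 2 stands at a limit: the limit of > 50000 nM in this assay, at which 2 of the 3 values shown sit.

Open, as far as these compounds go, is which part of (3-phenylpropyl)amino carries the step: the aromatic ring, the chain or the amide hydrogen. A shorter benzylamino group, or a plain propylamino group without the ring, would separate these parts.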